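Three aryl variants on a shared core, and a fourth to test

The source may report more compounds than this note shows. Statements on the series, on what has been measured and on what is new or still open speak of the compounds shown alone.

The three measured compounds share one core and differ only in the aryl group on a saturated ring carbon. In a functional assay on BGC-823 cells (Homo sapiens) for antiproliferative activity, read by MTT assay, tested at 5 uM (a higher number here means a stronger effect of the compound at the concentration tested, a lower number a weaker effect), compound 1 `COc1cc(C2=NN(C(C)=O)C(c3cc(Cl)cc(Cl)c3)O2)cc(OC)c1OC` gives 6.6%, compound 2 `COc1cc(C2=NN(C(C)=O)C(c3cccc(OC)c3OC)O2)cc(OC)c1OC` gives 17.5% and compound 3 `COc1cc(C2=NN(C(C)=O)C(c3ccc(C(F)(F)F)cc3)O2)cc(OC)c1OC` gives 3.4%. Compound 3 stands lowest of the three numbers: its gap to compound 1 lies within the scatter, while a number 14.1 percentage points lower from compound 2 to compound 3 (beyond the scatter) goes beyond it. Compound 4 `COc1cc(C2=NN(C(C)=O)C(c3ccc(Cl)c([N+](=O)[O-])c3)O2)cc(OC)c1OC` is the next member of the series. Its change from compound 3 is 4-chloro-3-nitrophenyl in place of 4-(trifluoromethyl)phenyl on a saturated ring carbon. Among the compounds with values here, the step that bears most directly on this is a number 3.2 percentage points lower from compound 1 to compound 3 (within the scatter), which left the read-out essentially unchanged; the only larger step, a number 10.9 percentage points higher from compound 1 to compound 2 (beyond the scatter), belongs to compound 2 and not to this route. With compound 1 and compound 3 both sitting low, no step beyond the scatter is expected for compound 4, and a number 3.6 percentage points higher from compound 3 to compound 4 (within the scatter) is the expected change. The estimate for compound 4 is 7%, with a range from 0% to 20%.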

Compound 4, a percentage reported as inhibition, at one concentration (the size of the read-out at that concentration, not a potency): 0%
For compound 4 the middle estimate is 7 percentage points above the measured one, and the stated range covers the measured number.
By their numbers in this assay, from the lowest: compounds 4, 3 and 1 (each within the scatter of the next); then compound 2.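

In this assay the 4-chloro-3-nitrophenyl group reads much like the two other aryl groups without methoxy substituents, with a number 3.4 percentage points lower from compound 3 to compound 4 (within the scatter) and a number 6.6 percentage points lower from compound 1 to compound 4 (within the scatter); a nitro-bearing ring with hydrogen-bond acceptors, which the 4-(trifluoromethyl)phenyl lacks, therefore gives no step beyond the scatter at this saturated ring carbon. Among the listed compounds only compound 2 stands apart, and the new comparison widens the separation with a number 17.5 percentage points lower from compound 2 to compound 4 (beyond the scatter). Nothing available here explains why these aryl groups read alike or why the 2,3-dimethoxyphenyl group differs.

The compounds shown leave open whether the higher reading of compound 2 depends on having both methoxy groups or on where they sit. They also leave open how an amine or a carboxylic acid on this aryl ring would read.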